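This account rests on a few compounds, and the source may have more. Where it says the series, first, only, none or still open, it means among the compounds named here.

Measured in a functional assay on HeLa cells (Homo sapiens) for inhibition, read by CCK-8 assay, with a stated time of 48 h; a higher number here means a weaker inhibitor, a lower number a stronger inhibitor:
- compound 1 `COc1cc(-c2ccnc3cc(-c4ccc(C)cc4)nn23)cc(OC)c1OC`: 21 nM
- compound 2 `COc1ccc(-c2cc3nccc(-c4cc(OC)c(OC)c(OC)c4)n3n2)cc1`: 373 nM

Compound 2 holds the higher of these two numbers. Compound 3 `COc1cc(-c2ccnc3cc(-c4ccc(-c5cnn(C)c5)cc4)nn23)cc(OC)c1OC` has 1-methyl-1H-pyrazol-4-yl in place of methoxy on an aromatic carbon. For the measured compounds named here, the only measured step at this place is an 18-fold higher number from compound 1 to compound 2 (1.25 log units; beyond the scatter), which is large and replaces methyl with methoxy. That step does not include the pyrazolyl group and gives no direction for the new change. In this assay, no step beyond the scatter is therefore expected, and the estimated step is a 1.2-fold lower number from compound 2 to compound 3 (0.09 log units; within the scatter). For compound 3 the estimated value is 300 nM, with an expected range of 40 nM to 2000 nM.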

Compound 3, half-maximal inhibitory concentration: 1830 nM
The estimate for compound 3 lay 6.1-fold (0.79 log units) below the measured number, and the stated range covers the measured number.
By their numbers in this assay, from the lowest: compound 1; then compound 2; then compound 3.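

In this assay, the aromatic carbon para to a large group now has a third substituent, and 1-methyl-1H-pyrazol-4-yl gives a 4.9-fold higher number from compound 2 to compound 3 (0.69 log units; beyond the scatter) and an 87-fold higher number from compound 1 to compound 3 (1.94 log units; beyond the scatter). Methyl, methoxy and 1-methyl-1H-pyrazol-4-yl now stand in that order from the lowest number, with every step beyond the scatter, so the five-membered aromatic ring does not recover the loss seen with methoxy. No available evidence accounts for this order.

On these data alone, whether any group at this carbon gives a lower number than methyl remains open. Chlorine, an amine or a carboxylic acid here would test how far the order extends.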